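This account rests on a few compounds, and the source may have more. Where it says the series, first, only, none or still open, it means among the compounds named here.

Series notes. Compound 1 `CCN1CCc2c(sc(NC(=O)Nc3ccc(Cl)cc3)c2C#N)C1` is the reference point in a functional assay (strain AB) with Danio rerio as the target, read by microscopy, with a stated time of 1 h; a lower number here means that less compound is needed, a higher number that more compound is needed for the effect. In this assay compound 1 gives > 25000 nM, which is a limit of the assay and not a number. Compound 2 `CCC(C)(C)C1CCc2c(sc(NC(=O)Nc3ccc(Cl)cc3)c2C(N)=O)C1` belongs to the same set. In this assay compound 2 gives > 25000 nM, again a limit and not a number. Compound 1 thus stands at the limit of > 25000 nM in this assay, at which 2 of the 2 values shown sit; no measured step between two compounds exists, so nothing about the size of any change has been shown yet. Compound 3 `CCN1CCc2c(sc(NC(=O)Nc3ccc(Cl)cc3)c2C(=O)c2nc(C)no2)C1` is the next compound, differing from compound 1 by a group of 8 heavy atoms (4 carbon, 2 nitrogen, 2 oxygen; one five-membered aromatic ring with 3 hetero atoms) in place of a group of 2 heavy atoms (1 carbon, 1 nitrogen; no ring), on an aromatic carbon. With compound 1 known only as a limit, the step to compound 3 in this assay rests on nothing measured; a step beyond the scatter in either direction cannot be excluded, but none beyond it is expected. Compound 3 is expected to give 25000 nM in this assay, between 6000 nM and 60000 nM. The expected step is a number no higher from compound 1 to compound 3 (the limit leaves the size open), with a limit again the likeliest outcome.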

Compound 3, half-maximal effective concentration: > 25000 nM
Compound 3: a limit, no number; the forecaster's own chance of this, stated with the estimate: 60%; the middle value lies on the limit itself.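

For the compounds shown here, compound 3 gives > 25000 nM in this assay, which is a limit and not a number; compound 1 also sits at a limit, so no step from compound 1 to compound 3 can be read. The compounds shown leave open what structure on this shared core would give a measurable effective concentration, with every value so far at one limit: the limit of > 25000 nM in this assay, at which 3 of the 3 values shown sit.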